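The source may hold more compounds than are shown below. What is called first, only, known or untested is meant among the compounds shown, and "the series" means these compounds.

Measured so far in a functional assay on HCT-15 cells (Homo sapiens) for inhibition; on this read-out higher numbers stand for weaker inhibition and lower numbers for stronger inhibition:
- compound 1 `Oc1ccccc1-c1cc(-c2cccc(F)c2)cc(-c2ccccc2O)n1`: > 50000 nM, a limit of the assay and not a number
- compound 2 `Oc1ccccc1-c1cc(-c2ccccc2C(F)(F)F)cc(-c2ccccc2O)n1`: 3970 nM

Going by the values given here, compound 2 holds the only true number so far, 3970 nM, so it is the sole firm reference point. Compound 3 `Oc1ccccc1-c1cc(-c2ccc(C(F)(F)F)cc2)cc(-c2ccccc2O)n1` has the same atoms, joined differently: 4-(trifluoromethyl)phenyl in place of 2-(trifluoromethyl)phenyl on an aromatic carbon, opposite the ring nitrogen (4-(trifluoromethyl)phenyl in place of 2-(trifluoromethyl)phenyl on an aromatic carbon).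

Among the compounds with values here, one measured step bears on this place: an at least 12-fold lower number from compound 1 to compound 2 (1.10 log units; beyond the scatter). That large change put 2-(trifluoromethyl)phenyl in place of 3-fluorophenyl, showing that this place can matter greatly. Within the data shown here, no measured pair moves the trifluoromethyl group alone, so the forecast is loose. Since the group stays, a small drift toward weaker inhibition in this assay is expected, with no clear step beyond the scatter. The expected step is a 1.5-fold higher number from compound 2 to compound 3 (0.18 log units; within the scatter). The estimated value for compound 3 is 6000 nM, with an expected range from 1500 nM to 30000 nM.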

Compound 3, half-maximal inhibitory concentration: > 50000 nM
Compound 3: no number, only a limit; the forecaster's own chance of this, stated with the estimate: 20%; middle value at least 8.3-fold (0.92 log units) from the limit.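

In this assay, moving the trifluoromethyl group to a different place on the same phenyl ring, with no atom gained or lost, gives an at least 12-fold higher number from compound 2 to compound 3 (1.10 log units; beyond the scatter). The earlier step, an at least 12-fold lower number from compound 1 to compound 2 (1.10 log units; beyond the scatter), changed both the substituent and where it sat, whereas this pair shows that the location of the trifluoromethyl group alone can separate a measurable result from none within the tested range. The step between compound 1 and compound 3 cannot be read, because both values are limits of the assay: the limit of > 50000 nM in this assay, at which 2 of the 3 values shown sit.

Among the compounds shown, only the 2-(trifluoromethyl)phenyl group gives a true number. As far as these compounds go, it remains open how 3-(trifluoromethyl)phenyl would behave, and whether another group in the same location as the trifluoromethyl of compound 2, such as 2-methoxyphenyl or 2-chlorophenyl, would give a similar value.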